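Working notes: amino analogue of compound 2 awaiting measurement

The source may hold more compounds than are shown below. What is called first, only, known or untested is meant among the compounds shown, and "the series" means these compounds.

Measured so far:
Compound 1 `COc1cc(-n2ncnc2-c2ccc(OC(C)C)cc2)cc(OC)c1OC` gives 800 nM in a functional assay on K562 cells (Homo sapiens) for antiproliferative activity, read by MTT assay, with a stated time of 72 h; on this read-out lower numbers stand for stronger inhibition and higher numbers for weaker inhibition.
Compound 2 `COc1cc(-c2ncnn2-c2ccccc2)cc(OC)c1OC` gives only a limit in this assay, namely > 10000 nM.
Compound 3 `COc1cc(-c2ncnn2-c2cccc([N+](=O)[O-])c2)cc(OC)c1OC` also gives only a limit in this assay, namely > 10000 nM.

Compound 2 therefore stands at the limit of this assay and carries no number; two of the three values shown sit at this limit (the limit of > 10000 nM in this assay, at which 2 of the 3 values shown sit). Within the data shown here, compound 1 is the only measured compound with a number, but it differs from compound 2 in more than one place, so its value says nothing about any single change. Among the measured compounds shown here, the one step between measured compounds that differ in one place, a step that the two limits leave unreadable from compound 2 to compound 3, runs between two limits and its size cannot be read.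

Compound 4 `COc1cc(-c2ncnn2-c2ccc(N)cc2)cc(OC)c1OC` differs from compound 2 by amino in place of hydrogen on an aromatic carbon. For the measured compounds named here, no measured step gives a size for this change, and the only step of a one-place change is unreadable. Compound 4 is therefore expected to remain most likely at the limit of this assay, with a step that the limit leaves unreadable from compound 2 to compound 4 expected as the central guess. Compound 4 is estimated at 12000 nM, in a range from 3000 nM to 40000 nM.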

Compound 4, half-maximal inhibitory concentration: > 10000 nM
Compound 4 ended at the assay's limit (the forecaster's own chance of this, stated with the estimate: 65%); the middle value lies beyond the limit too.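

In this assay compound 4 gives > 10000 nM, which is a limit and not a number. Compound 2 also stands at a limit, so no step can be read between compound 2 and compound 4. Left open is which single change to compound 2 would give a readable number, with the series standing here: the limit of > 10000 nM in this assay, at which 3 of the 4 values shown sit.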